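Aryl amide variation on the shared core, growth inhibition

A few compounds are considered here, and "the series" means these few. Any claim that something is new, unique, unknown or untested is made for them only; others in the source may bear on it.

Measured so far:
Compound 1 `CN(C)C(=O)c1cc2cnc(Nc3ccc(NC(=O)C4(C(=O)Nc5ccc(Cl)c(C(F)(F)F)c5)CC4)cc3)nc2n1C1CCCC1` gives 88.1% in a functional assay on A549 cells (Homo sapiens) for inhibition, read by CCK-8 assay, with a stated time of 72 h, tested at 10 uM; on this read-out higher numbers stand for more inhibition of growth at the one concentration tested and lower numbers for less inhibition of growth.
Compound 2 `COc1cccc(NC(=O)C2(C(=O)Nc3ccc(Nc4ncc5cc(C(=O)N(C)C)n(C6CCCC6)c5n4)cc3)CC2)c1` gives 96% in this assay.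
Compound 3 `CN(C)C(=O)c1cc2cnc(Nc3ccc(NC(=O)C4(C(=O)Nc5ccc(O)cc5)CC4)cc3)nc2n1C1CCCC1` gives 94.4% in this assay.

Compound 1 holds the lowest of the three numbers, though neither gap is beyond the scatter: the nearest is a number 6.3 percentage points higher from compound 1 to compound 3 (within the scatter) and the furthest is a number 7.9 percentage points higher from compound 1 to compound 2 (within the scatter). The remaining pair, a number 1.6 percentage points lower from compound 2 to compound 3 (within the scatter), is likewise within the scatter, so the three measured compounds cannot be ordered.

Compound 4 `CN(C)C(=O)c1cc2cnc(Nc3ccc(NC(=O)C4(C(=O)Nc5ccc(C#N)cc5)CC4)cc3)nc2n1C1CCCC1` is not yet measured. Its difference from compound 1 is 4-cyanophenyl in place of 4-chloro-3-(trifluoromethyl)phenyl on an amide-type nitrogen. The two steps that bear on it are those in which the same 4-chloro-3-(trifluoromethyl)phenyl group was exchanged for another aryl group on that amide-type nitrogen, namely a number 7.9 percentage points higher from compound 1 to compound 2 (within the scatter) and a number 6.3 percentage points higher from compound 1 to compound 3 (within the scatter); both stayed within the scatter, in the upward direction. For compound 4 a step of similar character is therefore expected in this assay, small and within the scatter, as a number 4.9 percentage points higher from compound 1 to compound 4 (within the scatter). The expected value for compound 4 is 93%, with a range from 82% to 99%.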

Compound 4, percent growth inhibition at one concentration: 95%
Beside the measured number, compound 4's estimate is 2 percentage points below it; measured number inside the range.
By their numbers in this assay, from the lowest: compounds 1, 3, 4 and 2 (each within the scatter of the next).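

In this assay the 4-cyanophenyl group on the amide-type nitrogen is a third replacement for 4-chloro-3-(trifluoromethyl)phenyl whose step stays inside the scatter (a number 6.9 percentage points higher from compound 1 to compound 4 (within the scatter)). It also cannot be separated from the other two aryl groups, either for cyano in place of hydroxy on an aromatic carbon (a number 0.6 percentage points higher from compound 3 to compound 4 (within the scatter)) or for the exchange with 3-methoxyphenyl (a number 1 percentage points lower from compound 2 to compound 4 (within the scatter)), so compounds 1, 2, 3 and 4 cannot be ordered at the one concentration tested. No evidence at hand bears on this result.

On these data alone, whether a morpholine, a carboxylic acid or an aminomethyl group on that aryl ring would give a number in the same range remains open. Also open, as far as these compounds go, is whether a cyclohexyl group or a short alkyl chain could stand in place of the aryl ring on that nitrogen.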